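This account rests on a few compounds, and the source may have more. Where it says the series, first, only, none or still open, it means among the compounds named here.

Measured in a functional assay on MCF7 cells (Homo sapiens) for antiproliferative activity, read by MTT assay, with a stated time of 48 h; on this read-out higher numbers stand for weaker inhibition and lower numbers for stronger inhibition:
- compound 1 `Cc1ccc(S(=O)(=O)NC(=O)/C=C/c2ccc3c(c2)OCCCO3)cc1`: > 100 ug/mL (a limit)
- compound 2 `O=C(/C=C/c1ccc2c(c1)OCCCO2)NS(=O)(=O)c1ccc(F)cc1`: > 100 ug/mL (a limit)

Compound 2 stands at > 100 ug/mL, which is a limit and not a number. The next compound to be read is compound 3 `O=C(/C=C/c1ccc2c(c1)OCCCO2)NS(=O)(=O)c1ccc(Cl)cc1`, which has chloro in place of fluoro on an aromatic carbon, para to a large group: chloro in place of fluoro on an aromatic carbon. For the measured compounds named here, the one measured step that bears on this change is a step that the two limits leave unreadable from compound 1 to compound 2. It also concerns the same aromatic carbon, but it gives no size to carry over. Going by the values given here, the series so far shows only (the limit of > 100 ug/mL in this assay, at which 2 of the 2 values shown sit). No step beyond the scatter is therefore expected in this assay, and no direction can be assigned. The expected step is a number no higher from compound 2 to compound 3 (the limit leaves the size open). The estimate for compound 3 is 100 ug/mL, with an expected range of 25 ug/mL to 200 ug/mL.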

Compound 3, half-maximal inhibitory concentration: > 100 ug/mL
Compound 3 was reported as a limit (the forecaster's own chance of this, stated with the estimate: 65%); the middle value sits exactly at the limit.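

No new step can be read: compound 1, compound 2 and compound 3 each stand in this assay only as a limit and not as a number. The compounds shown leave open the size and direction of any step among methyl, fluoro and chloro.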